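Benzoyl Substituent Swap on a Triazene Scaffold

The compounds below may be only part of what the source reports. "The series", "measured", "known", "first", "only" and "open" are said of these compounds alone.

Measured compounds:
compound 1 `O=C(c1ccc(F)cc1)N(/N=N/c1ccc([N+](=O)[O-])cc1Br)c1ccc([N+](=O)[O-])cc1Br` — 580 nM
compound 2 `O=C(c1ccccc1)N(/N=N/c1ccc([N+](=O)[O-])cc1C(F)(F)F)c1ccc([N+](=O)[O-])cc1C(F)(F)F` — 600 nM
compound 3 `O=C(c1ccccc1F)N(/N=N/c1ccc([N+](=O)[O-])cc1C(F)(F)F)c1ccc([N+](=O)[O-])cc1C(F)(F)F` — 800 nM

Three compounds have been characterised in a functional assay on HeLa cells (Homo sapiens) for cytotoxicity, read by MTT assay, with a stated time of 72 h; on this read-out lower numbers stand for stronger inhibition and higher numbers for weaker inhibition. Compound 3 gives the highest of the three numbers, yet its separation from the other two is small: compound 2 sits closer, and compound 1 furthest, and both gaps stay within the scatter of the method. Going by the values given here, compound 2 and compound 3 share the same core, and the only step between them is a 1.3-fold higher number from compound 2 to compound 3 (0.12 log units; within the scatter).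

The unmeasured compound 4 `O=C(c1ccc(C(F)(F)F)cc1)N(/N=N/c1ccc([N+](=O)[O-])cc1C(F)(F)F)c1ccc([N+](=O)[O-])cc1C(F)(F)F` is reached from compound 3 by one change: 4-(trifluoromethyl)phenyl in place of 2-fluorophenyl on a carbonyl carbon. Among the compounds with values here, no measured step covers this exact exchange. Within the data shown here, the one step that touches the same carbonyl-bound ring, from compound 2 to compound 3, was within the scatter, and compound 1, which carries a fluorine on that ring in a different position on a different core, falls in the same narrow band as the others. On this evidence the change is expected to move the number little, with a 1.1-fold lower number from compound 3 to compound 4 (0.06 log units; within the scatter) as the estimated step in this assay.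

Compound 4 is therefore expected to give about 700 nM, within a range from 350 nM to 1500 nM.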

Compound 4, half-maximal inhibitory concentration: 690 nM
Compound 4: middle estimate off by 1.0-fold (0.01 log units), on the high side; the measured number falls inside the stated range.
By their numbers in this assay, from the lowest: compounds 1, 2, 4 and 3 (each within the scatter of the next).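

Placing 4-(trifluoromethyl)phenyl instead of 2-fluorophenyl on the carbonyl carbon gives a 1.2-fold lower number from compound 3 to compound 4 (0.06 log units; within the scatter) in this assay and shows that this exchange of one substituted ring for another leaves the number within the scatter. Adding a trifluoromethyl group to the same ring gives a 1.2-fold higher number from compound 2 to compound 4 (0.06 log units; within the scatter) and adds a second substituent to the single fluoro step previously available on the shared core. Across compound 2, compound 3 and compound 4, therefore, the ring on the carbonyl carbon carries hydrogen, fluoro or trifluoromethyl substituents with no step beyond the scatter, although no other measurement bears on why the numbers stay so close.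

Going by these compounds, it remains open whether this holds for an amine, a hydroxyl or a carboxylic acid on that ring, or for a longer alkyl chain in place of the ring on the carbonyl carbon. On these data alone, it also remains open whether trifluoromethyl in place of hydrogen on that ring would give a similar step on the core of compound 1.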